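Trading 1-(4-fluorophenyl)ethyl for benzyl on the amide

The source may hold more compounds than are shown below. What is called first, only, known or untested is meant among the compounds shown, and "the series" means these compounds.

This small set of compounds was tested in a functional assay on HCT-116 cells (Homo sapiens) for cytotoxicity, read by MTT assay, with a stated time of 72 h; a higher number here means a weaker inhibitor, a lower number a stronger inhibitor. Compound 2 `C[C@H](NC(=O)c1nc(Br)c2cccnc2c1N[C@H]1CC[C@H](N)CC1)c1ccc(F)cc1` gives > 10000 nM, which is a limit of the assay and not a number. Across the set, that means (the limit of > 10000 nM in this assay, at which 1 of the 3 values shown sits). Among the measured compounds shown here, compound 3 `O=CNCCCCCCNc1nc(C(=O)NCc2ccc(F)cc2)c(O)c2ncccc12` gives 4000 nM, the only plain number available. For compound 1 `N[C@H]1CC[C@H](Nc2c(C(=O)NCc3ccc(Oc4ccccc4)cc3)nc(Br)c3cccnc23)CC1`, the entry in this assay is "not determined" (no result reported), so it offers no guidance.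

The next compound to consider is compound 4 `N[C@H]1CC[C@H](Nc2c(C(=O)NCc3ccccc3)nc(Br)c3cccnc23)CC1`. It differs from compound 2 in one place, with benzyl in place of 1-(4-fluorophenyl)ethyl on an amide-type nitrogen. Both groups carry one six-membered aromatic ring of carbon only, and the rest of the structure stays the same.

For the measured compounds named here, no measured pair in this set differs in just one place, so the size of this change has no direct precedent. The expectation therefore rests on compound 2 and its limit of > 10000 nM. In this assay, no step beyond the usual scatter is expected, and the estimated change is a number no higher from compound 2 to compound 4 (the limit leaves the size open). A report of only a limit would be no surprise. For compound 4, the expected value is 10000 nM, with an estimated range from 3000 nM to 30000 nM.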

Compound 4, half-maximal inhibitory concentration: 7000 nM
For compound 4 the middle estimate is 1.4-fold (0.15 log units) above the measured one, within the range that was stated.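

Among the compounds shown here, compound 4 forms the first pair in this set that differs in only one place, and in this assay that pair gives an at least 1.4-fold lower number from compound 2 to compound 4 (0.15 log units; that floor lies within the scatter). The change on the amide-type nitrogen removes a fluorine and a defined stereocentre together, yet both compounds keep one six-membered aromatic ring of carbon only, and compound 4 gives a plain number, 7000 nM, that later comparisons at this position can build on. The step remains only a floor, since compound 2 gives > 10000 nM, which is a limit and not a number: the limit of > 10000 nM in this assay, at which 1 of the 4 values shown sits.

The compounds shown leave open whether the fluorine or the branching carbon of 1-(4-fluorophenyl)ethyl matters more, a question that 4-fluorobenzyl or 1-phenylethyl on the same nitrogen could separate, since each keeps only one of the two features. They also leave open how this position would respond to a group of a different kind, such as a 2-phenylethyl with its longer chain or a benzyl carrying a carboxylic acid.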